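Trifluoromethoxy for chloro on the benzyl arm

The source may hold more compounds than are shown below. What is called first, only, known or untested is meant among the compounds shown, and "the series" means these compounds.

Compound 2 `Cn1cc(SCc2nnc(SCc3ccccc3Cl)n2-c2c(Cl)cccc2Cl)c2ccccc21` gives 49600 nM in a toxicity assay on HEK-293T cells (Homo sapiens) for cytotoxicity, read by CCK-8 assay, with a stated time of 48 h (a higher number here means that more compound is tolerated, a lower number that less compound is tolerated), the lowest of the two numbers seen; its nearest neighbour is compound 1 `Cn1cc(SCc2nnc(SCc3ccccc3C#N)n2-c2c(Cl)cccc2Cl)c2ccccc21`, which gives 78600 nM. Among the compounds with values here, the one step at this position, a 1.6-fold lower number from compound 1 to compound 2 (0.20 log units; within the scatter), stayed within the scatter. Compound 3 `Cn1cc(SCc2nnc(SCc3ccccc3OC(F)(F)F)n2-c2c(Cl)cccc2Cl)c2ccccc21` carries trifluoromethoxy in place of chloro on an aromatic carbon. Within the data shown here, no measured step covers this exchange, so on the single neighbouring step that does exist, no shift beyond the scatter is expected, a 1.0-fold higher number from compound 2 to compound 3 (0.00 log units; within the scatter). Compound 3 is therefore estimated at 50000 nM in this assay, with a range from 25000 nM to 100000 nM.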

Compound 3, half-maximal cytotoxic concentration: > 100000 nM
Compound 3 ended at the assay's limit; the forecaster's own chance of this, stated with the estimate: 10%; middle value at least 2.0-fold (0.30 log units) from the limit.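

Within the data shown here, at this place on the benzyl arm, trifluoromethoxy is the only one of the three groups whose reading in this assay reaches a limit rather than a number: the limit of > 100000 nM in this assay, at which 1 of the 3 values shown sits. Read from that limit, the change gives an at least 2.0-fold higher number from compound 2 to compound 3 (0.30 log units; that floor lies within the scatter) and an at least 1.2-fold higher number from compound 1 to compound 3 (0.10 log units; that floor lies within the scatter) as floors only, and both floors lie within the scatter, so the true size of neither step is known. The compounds shown leave open how far past its limit compound 3 lies, and whether an amine or a carboxylic acid on this aromatic carbon would give a different reading.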